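The compounds below may be only part of what the source reports. "The series", "measured", "known", "first", "only" and "open" are said of these compounds alone.

Notes on the series. Compound 1 `CC(=O)N[C@@H]1CCN(c2cc(C)nn3c(-c4cccs4)c(C)nc23)C1`, compound 2 `COc1ccc(-c2c(C)nc3c(N4CC[C@@H](NC(C)=O)C4)cc(Cl)nn23)cc1OC` and compound 3 `COc1ccc(-c2c(C)nc3c(N4CC[C@@H](NC(=O)COc5ccccc5)C4)cc(C)nn23)cc1OC` share one core and have all been run in an ADME assay on microsomes from liver (Homo sapiens) for metabolic stability, read by LC-MS, with NADPH named in the record, with a stated time of 60 min, tested at 1 uM, in the absence of a further agent; a lower number here means that less of the compound is left, a higher number that more of the compound is left. In this assay compound 1 gives > 95%, which is a limit of the assay and not a number. Compound 2 gives > 95%, again a limit. Compound 3 gives > 95%, also a limit. Within the data shown here, compound 3 therefore stands where every value so far stands, since the limit of > 95% in this assay, at which 3 of the 3 values shown sit, holds for all three, and no step between measured compounds that differ in a single place is known from these data.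

Compound 4 `COc1ccc(-c2c(C)nc3c(N4CC[C@@H](NS(=O)(=O)c5ccc(C(C)=O)cc5)C4)cc(C)nn23)cc1OC` has not yet been measured in this assay. Relative to compound 3 it carries (4-acetylphenyl)sulfonyl in place of (phenoxymethyl)carbonyl on an amine nitrogen. Among the measured compounds shown here, with no measured step of this kind to lean on, and compound 3 sitting at the limit with > 95%, the step from compound 3 to compound 4 is expected to be none beyond the scatter, or a small fall. Compound 4 is expected to give 90%, within 72% to 100%. The expected step is a number at least 5 percentage points lower from compound 3 to compound 4 (that floor lies within the scatter).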

Compound 4, percent of the compound remaining: > 95%
Compound 4 ended at the assay's limit; the forecaster's own chance of this, stated with the estimate: 55%; middle value at least 5 percentage points away from the limit.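

No step from compound 3 to compound 4 can be read in this assay, because both values are limits of the assay and not numbers: the limit of > 95% in this assay, at which 4 of the 4 values shown sit.

The compounds shown leave open what (4-acetylphenyl)sulfonyl in place of (phenoxymethyl)carbonyl on an amine nitrogen does to the percent of compound remaining, and which changes to the series would bring a value off the limit.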